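Swapping the Carboxyphenyl for a Thiazolyl Group

This account rests on a few compounds, and the source may have more. Where it says the series, first, only, none or still open, it means among the compounds named here.

Of the compounds shown here, three sharing one core have been measured in a functional assay on HEK293 cells for agonist activity at Bombesin receptor subtype-3 (Mus musculus), read by luminescence and calcium flux, with a stated time of 10 min; a higher number here means that more compound is needed for the effect, a lower number that less compound is needed. Compound 1 `CCC(C)(C)Cc1c[nH]c(CCc2ccc(-n3cccn3)cc2)n1` gives 113 nM, compound 2 `CCC(C)(C)Cc1c[nH]c(CCc2ccc(-n3ccnn3)cc2)n1` gives 111 nM, and compound 3 `CCC(C)(C)Cc1c[nH]c(CCc2ccc(-c3ccccc3C(=O)O)cc2)n1` gives 94 nM. Compound 3 carries the lowest of the three numbers, but the gaps are small: a 1.2-fold lower number from compound 1 to compound 3 (0.08 log units; within the scatter) and a 1.2-fold lower number from compound 2 to compound 3 (0.07 log units; within the scatter), both within the scatter, as is a 1.0-fold lower number from compound 1 to compound 2 (0.01 log units; within the scatter). The next compound, compound 4 `CCC(C)(C)Cc1c[nH]c(CCc2ccc(-c3cnsc3)cc2)n1`, differs from compound 3 in one place: 1,2-thiazol-4-yl in place of 2-carboxyphenyl on an aromatic carbon. Within the data shown here, the steps that bear on this change are those from compounds 1 and 2 to compound 3, where a five-membered aromatic ring with two hetero atoms gave way to the 2-carboxyphenyl group without any step beyond the scatter. Compound 4 brings a five-membered aromatic ring with two hetero atoms back to the same position, so no step beyond the scatter is expected in this assay, in either direction. For compound 4 the estimate in this assay is 110 nM, within 55 nM to 220 nM, which corresponds to an expected step of a 1.2-fold higher number from compound 3 to compound 4 (0.07 log units; within the scatter).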

Compound 4, half-maximal effective concentration: 119 nM
The estimate for compound 4 lay 1.1-fold (0.03 log units) below the measured number, and the stated range covers the measured number.
By their numbers in this assay, from the lowest: compounds 3, 2, 1 and 4 (each within the scatter of the next).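

In this assay the 1,2-thiazol-4-yl group gives a 1.3-fold higher number from compound 3 to compound 4 (0.10 log units; within the scatter) and a 1.1-fold higher number from compound 2 to compound 4 (0.03 log units; within the scatter) and a 1.1-fold higher number from compound 1 to compound 4 (0.02 log units; within the scatter) on this aromatic carbon, para to a large group. This shows that a ring with sulfur and nitrogen, joined through carbon, sits within the scatter of all three earlier groups, and that going from the 9 heavy atoms and 1 hydrogen-bond donor of 2-carboxyphenyl to 5 heavy atoms and 0 hydrogen-bond donors moved no step beyond it. No measurement is available that would explain these small steps.

The four compounds leave open whether any group at this position can produce a step beyond the scatter. A simple amine or a longer chain in place of these rings remains an untested question in the compounds shown here.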